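Dropping the drawn configuration at the ring stereocentre

The source may report more compounds than this note shows. Statements on the series, on what has been measured and on what is new or still open speak of the compounds shown alone.

Measured compounds:
compound 1 `C=CCN(c1ccccc1)S(=O)(=O)c1ccc(Cl)cc1`, 310 nM
compound 2 `O=S(=O)(c1ccc(Cl)cc1)N1CCC[C@@H]1c1cccs1`, 230 nM
compound 3 `O=S(=O)(c1ccc(Cl)cc1)N1CCC[C@H]1c1cccs1`, 450 nM

In a functional assay on cardiac atrium (Cavia porcellus) (a lower number here means that less compound is needed, a higher number that more compound is needed for the effect), compound 2 gives 230 nM, the lowest of the three numbers, yet its gap to compound 1 and its gap to compound 3 both lie within the scatter, so no order among the three can be read from them. Compound 4 `O=S(=O)(c1ccc(Cl)cc1)N1CCCC1c1cccs1` has not yet been measured in this assay. It differs from compound 2 in this way: the two compounds have the same atoms and bonds; at least one stereo element is drawn with a configuration in one of them and without one in the other: 1 of 1 stereo elements differ; a stereocentre at a saturated ring carbon is drawn R in compound 2 and without a configuration in compound 4. Among the compounds with values here, one measured step bears on this change, the one between the two drawn configurations of the same ring stereocentre, where a 2.0-fold higher number from compound 2 to compound 3 (0.29 log units; within the scatter), a step resting on (the fact that compounds 2 and 3 differ only in the configuration as drawn). Since that step stays within the scatter, compound 4, drawn without a configuration at that carbon, is expected to land in this assay close to both compound 2 and compound 3, with no step beyond the scatter in either direction. For compound 4 the estimate is 320 nM, within a range from 160 nM to 640 nM. The expected step from compound 2 is a 1.4-fold higher number from compound 2 to compound 4 (0.14 log units; within the scatter).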

Compound 4, half-maximal effective concentration: 310 nM
Beside the measured number, compound 4's estimate is 1.0-fold (0.01 log units) above it; low and high end bracket the measured number.
By their numbers in this assay, from the lowest: compounds 2, 1, 4 and 3 (each within the scatter of the next).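

In this assay this carbon can now be read in three drawings, R, S and without a configuration. The step from the R drawing (a 1.3-fold higher number from compound 2 to compound 4 (0.13 log units; within the scatter)) and the step from the S drawing (a 1.5-fold lower number from compound 3 to compound 4 (0.16 log units; within the scatter)) both lie within the scatter. The earlier pair showed this only for the two defined drawings; with compound 4 added, none of the three separates from the others, so for these compounds the way this stereocentre is drawn gives no readable difference in this assay.

On these data alone, whether that holds once the shared core carries an amine or a carboxylic acid stays open. Also open, as far as these compounds go, is what share of each configuration compound 4 holds, and whether a change of group at this carbon, rather than of its configuration, would move the number beyond the scatter.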